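Fluoro for Trifluoromethyl: Expected Solubility of Compound 4

A few compounds are considered here, and "the series" means these few. Any claim that something is new, unique, unknown or untested is made for them only; others in the source may bear on it.

Of the compounds shown here, three built on one shared core have been measured in a physicochemical assay for solubility, using the shake flask method, measured as kinetic solubility, with a stated time of 20 h, at pH 2; on this read-out lower numbers stand for lower solubility and higher numbers for higher solubility. Compound 1 `Fc1ccc(Nc2cc3[nH]c(-c4cccc(C(F)(F)F)c4)nc3cn2)nc1` returns < 5000 nM, which is a limit of the assay and not a number. Compound 2 `FC(F)(F)c1ccc(Nc2cc3[nH]c(-c4cccc(C(F)(F)F)c4)nc3cn2)nc1` likewise returns < 5000 nM, again a limit. Compound 3 `Fc1ccc(-c2nc3cnc(Nc4ccc(C(F)(F)F)cn4)cc3[nH]2)cc1F` is the only one of the three with a real number, giving 6000 nM in this assay.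

The change from compound 2 to compound 1 is fluoro in place of trifluoromethyl on an aromatic carbon. In this assay it makes a step that the two limits leave unreadable from compound 2 to compound 1, because both of its ends sit at the limit of < 5000 nM in this assay, at which 2 of the 3 values shown sit. The two cores of compound 2 and compound 3 differ by 3,4-difluorophenyl in place of 3-(trifluoromethyl)phenyl on an aromatic carbon, and that change makes an at least 1.2-fold higher number from compound 2 to compound 3 (0.07 log units; that floor lies within the scatter).

Compound 4 `Fc1ccc(Nc2cc3[nH]c(-c4ccc(F)c(F)c4)nc3cn2)nc1`, not yet measured, differs from compound 3 by fluoro in place of trifluoromethyl on an aromatic carbon. This is the same change as the one from compound 2 to compound 1, at a place described in the same words, so among the compounds shown it occurs twice in all. The measured instance of it could not be read, and compound 3 itself stands at 6000 nM.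

On that basis the step from compound 3 to compound 4 in this assay is expected to be about a 1.2-fold lower number from compound 3 to compound 4 (0.08 log units; within the scatter), essentially flat. Compound 4 is therefore estimated at 5000 nM, with a range from 2000 nM to 12000 nM, and with a real chance that the assay again reports only a limit.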

Compound 4, solubility: 42000 nM
Estimate against measurement, compound 4: 8.4-fold (0.92 log units) below, outside the stated range (above it).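

In this assay, fluoro in place of trifluoromethyl, on an aromatic carbon of a six-membered aromatic ring with 1 nitrogen, makes a 7.0-fold higher number from compound 3 to compound 4 (0.85 log units; beyond the scatter), and in that pair the other aryl group is 3,4-difluorophenyl on both sides. The same change where that group is 3-(trifluoromethyl)phenyl, going between compound 2 and compound 1, cannot be read, because both of its ends rest on a limit and not on a number: the limit of < 5000 nM in this assay, at which 2 of the 4 values shown sit. The series therefore offers one readable instance of this change, which shows that it can go with a clearly higher number on one version of the shared core, but it does not show that the step carries over to the other version, in size or even in direction, since nothing can be said of how compound 1 and compound 2 compare.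

As far as these compounds go, whether the step seen with compound 4 would recur with any other aryl group on the shared core remains open. Also open, from the compounds shown here alone, is whether a chloro, a nitrile or an amine in the same place as the fluoro would give a step of like size, which would say whether the step follows the fluoro that enters or the trifluoromethyl that leaves.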